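The compounds below may be only part of what the source reports. "The series", "measured", "known", "first", "only" and "open" are said of these compounds alone.

Compound 1 `O=C(Nc1ccc(Cl)cc1F)c1cc(Cl)ccc1O` has been examined in an ADME assay on RAW264.7 cells (Mus musculus) for cytotoxicity, read by MTT assay, with a stated time of 24 h (a lower number here means that less compound is tolerated, a higher number that more compound is tolerated), where compound 1 gives 8000 nM. Within the data shown here, only two numbers exist so far: the other compound, compound 2 `O=c1oc2ccc(Br)cc2c(=O)n1-c1ccc(I)cc1F`, gives 7900 nM in this assay, a figure that lies within the scatter of the number for compound 1, so the two cannot be told apart and compound 1 does not stand out from compound 2. The next compound, compound 3 `O=C(Nc1ccc(Br)cc1F)c1cc(Cl)ccc1O`, has not yet been measured. It differs from compound 1 in one place: bromo in place of chloro on an aromatic carbon, meta to a fluoro group and para to a large group. Among the measured compounds shown here, no measured pair shows the effect of this change, so the size of the step is unknown. The step is expected to be no change at the digits printed from compound 1 to compound 3 (within the scatter) and to lie in no particular direction beyond the scatter. Compound 3 is therefore estimated to give 8000 nM in this assay, within a range from 4000 nM to 16000 nM.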

Compound 3, half-maximal cytotoxic concentration: 7800 nM
Compound 3: middle estimate off by 1.0-fold (0.01 log units), on the high side; measured number inside the range.
By their numbers in this assay, from the lowest: compounds 3, 2 and 1 (each within the scatter of the next).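

In this assay, among these compounds, bromo in place of chloro on an aromatic carbon, meta to a fluoro group and para to a large group, gives a 1.0-fold lower number from compound 1 to compound 3 (0.01 log units; within the scatter), the first step that can be read in one place. At this position, chloro and bromo therefore cannot be told apart in this read-out, which compound 1 and compound 2 could not show, since they differ in more than one place. No supporting measurement is available to explain this result.

Still open, from the compounds shown here alone, is whether an amine, a methoxy group or a carboxylic acid at this position would leave the number equally unmoved, since both groups seen here are halogens. Also open, going by these compounds, is whether the same exchange at the second chloro group of compound 1 would give a similar step.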